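Replacing the ring on the thiocarbonyl carbon of compound 2

A few compounds are considered here, and "the series" means these few. Any claim that something is new, unique, unknown or untested is made for them only; others in the source may bear on it.

Of the compounds shown here, three sharing one core have been measured in a functional assay on A-431 cells (Homo sapiens) for cytotoxicity, read by MTT assay, with a stated time of 72 h, tested at 30 uM; on this read-out higher numbers stand for more inhibition of growth at the one concentration tested and lower numbers for less inhibition of growth. Compound 1 `Cc1ccnc(/C(N)=N/NC(=S)N2CCOCC2)c1` gives 74.6%, compound 2 `Cc1ccnc(/C(N)=N/NC(=S)N2CCSCC2)c1` gives 75.3%, and compound 3 `N/C(=N\NC(=S)N1CCSCC1)c1ccccn1` gives 81.3%. Compound 2 stands second highest of the three numbers, nearest to compound 1 and furthest from compound 3, and all three values lie within the scatter of one another: a number 0.7 percentage points higher from compound 1 to compound 2 (within the scatter) and a number 6 percentage points higher from compound 2 to compound 3 (within the scatter).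

Compound 4 `Cc1ccnc(/C(N)=N/NC(=S)N2CCCCC2)c1` is not yet measured. It differs from compound 2 in one place: piperidin-1-yl in place of thiomorpholin-4-yl on a thiocarbonyl carbon. The step that bears most directly on it is the exchange of one six-membered ring for another on the same thiocarbonyl carbon, a number 0.7 percentage points higher from compound 1 to compound 2 (within the scatter), which produced no shift beyond the scatter. On that basis, compound 4 is expected to show no step beyond the scatter in this assay, a number 0.3 percentage points lower from compound 2 to compound 4 (within the scatter). The estimate for compound 4 is 75%, within a range from 62% to 86%.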

Compound 4, percent growth inhibition at one concentration: 62.8%
Compound 4: middle estimate off by 12.2 percentage points, on the high side, and the stated range covers the measured number.
By their numbers in this assay, from the lowest: compound 4; then compounds 1, 2 and 3 (each within the scatter of the next).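

In this assay, the ring on the thiocarbonyl carbon proves not to be interchangeable: morpholin-4-yl and thiomorpholin-4-yl could not be told apart, but piperidin-1-yl brings a number 12.5 percentage points lower from compound 2 to compound 4 (beyond the scatter) and a number 11.8 percentage points lower from compound 1 to compound 4 (beyond the scatter). Among these three compounds, the two rings with 2 hetero atoms stand together, and piperidin-1-yl, with 1 hetero atom, stands apart from them. Nothing available explains this difference.

The compounds shown leave open whether piperazin-1-yl, a ring with a second nitrogen, would stand with compound 1 and compound 2 or with compound 4, and how an open-chain dimethylamino group on the same carbon would read. They also leave open whether piperidin-1-yl would bring a similar step on the core of compound 3, which carries hydrogen in place of methyl.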